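This account rests on a few compounds, and the source may have more. Where it says the series, first, only, none or still open, it means among the compounds named here.

Measured compounds:
compound 1, `CCN1CC[C@@]2(OC)OC(N)=C(C#N)[C@@H](c3ccc(Cl)cc3)[C@@H]2C1`, 14900 nM
compound 2, `CCN1CC[C@@]2(OC)OC(N)=C(C#N)[C@@H](c3ccc(OC)cc3)[C@@H]2C1`, 25500 nM
compound 3, `CO[C@@]12CCN(C)C[C@H]1[C@H](c1ccc(N3CCCCC3)cc1)C(C#N)=C(N)O2`, 19000 nM

All three values come from a functional assay on trachea (Cavia porcellus); a higher number here means a weaker inhibitor, a lower number a stronger inhibitor. Compound 3 stands second highest of the three numbers. Its nearest neighbour is compound 1, a little lower, and its furthest is compound 2, a little higher; both gaps lie within the scatter, so the three compounds cannot be told apart on these data. Among the compounds with values here, the only single-point step among them, a 1.7-fold higher number from compound 1 to compound 2 (0.23 log units; within the scatter), is also within the scatter.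

Compound 4, `CCN1CC[C@@]2(OC)OC(N)=C(C#N)[C@@H](c3ccc(N4CCCCC4)cc3)[C@@H]2C1`, differs from compound 3 by methyl in place of hydrogen on a saturated chain carbon bound to an amine nitrogen in a ring. Within the data shown here, no measured step bears directly on this change: the one step on record concerns the aromatic substituent, not the chain on the ring amine. Among the measured compounds shown here, compounds 1 and 2 do carry the ethyl chain that compound 4 carries, but they differ from compound 3 in the aromatic group as well, so they give no clean step. For the measured compounds named here, since every value so far sits within the scatter of every other, the step from compound 3 to compound 4 is expected to be small, a 1.1-fold lower number from compound 3 to compound 4 (0.05 log units; within the scatter), with no direction preferred. Compound 4 is therefore estimated at 17000 nM in this assay, with a range from 7000 nM to 40000 nM.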

Compound 4, half-maximal inhibitory concentration: 13800 nM
The estimate for compound 4 lay 1.2-fold (0.09 log units) above the measured number; the measured number falls inside the stated range.
By their numbers in this assay, from the lowest: compounds 4, 1, 3 and 2 (each within the scatter of the next).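

In this assay, the change of methyl to ethyl on the amine nitrogen in a ring can now be read with the piperidin-1-yl group held constant (a 1.4-fold lower number from compound 3 to compound 4 (0.14 log units; within the scatter)), and this clean pair does not separate the two chains. With the ethyl chain held constant, the aromatic carbon can also be read for piperidin-1-yl in place of methoxy (a 1.8-fold lower number from compound 2 to compound 4 (0.27 log units; within the scatter)) and piperidin-1-yl in place of chloro (a 1.1-fold lower number from compound 1 to compound 4 (0.03 log units; within the scatter)), so the piperidin-1-yl group cannot be told apart from either of the smaller groups in this set. No accompanying measurement gives a reason for these results.

Every comparison among the four compounds lies within the scatter. The compounds shown do not establish that either place can move the number, and they leave open whether a longer chain such as propyl or a benzyl group on that amine nitrogen would do so. They also leave open whether a morpholin-4-yl group or a carboxylic acid on the aromatic ring would give a step beyond the scatter.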